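The compounds below may be only part of what the source reports. "The series", "measured", "known", "first", "only" and "open" are said of these compounds alone.

Going by the values given here, in a functional assay on MDA-MB-231 cells (Homo sapiens) for antiproliferative activity, read by MTT assay, with a stated time of 48 h (a higher number here means a weaker inhibitor, a lower number a stronger inhibitor), three compounds have numbers so far. Compound 1 `C=CS(=O)(=O)N1CCN(c2nc(OC[C@H]3CCCN3C)nc3sc(-c4ccc(C#N)cc4)cc23)CC1` gives 3010 nM, compound 2 `C=CS(=O)(=O)N1CCN(c2ncnc3sc(-c4ccc(N5CCN(C)CC5)cc4)cc23)[C@@H](C)C1` gives 6180 nM, and compound 3 `CN1CCN(c2ccc(-c3cc4c(N5CCN(S(=O)(=O)N6CCCCC6)CC5)ncnc4s3)cc2)CC1` gives 8130 nM. Compound 3 therefore stands within the usual scatter of compound 2, while its number is higher than that of compound 1 by more than the scatter. Compound 4 `COc1ccc(NC(=O)N2CCN(c3ncnc4sc(-c5ccc(N6CCN(C)CC6)cc5)cc34)CC2)cc1` differs from compound 3 in one place, with (4-methoxyphenyl)carbamoyl in place of (piperidin-1-yl)sulfonyl on an amine nitrogen in a ring. Among the compounds with values here, no measured pair shows the effect of such a swap, so no step beyond the scatter is expected in this assay, in either direction. The expected step is a 1.4-fold lower number from compound 3 to compound 4 (0.13 log units; within the scatter). For compound 4 the estimated value is 6000 nM, with an expected range of 2000 nM to 18000 nM.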

Compound 4, half-maximal inhibitory concentration: 20900 nM
For compound 4 the middle estimate is 3.5-fold (0.54 log units) below the measured one; measured number outside the range, above it.
By their numbers in this assay, from the lowest: compound 1; then compounds 2 and 3 (each within the scatter of the next); then compound 4.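

In this assay, the substituent on this amine nitrogen in a ring does matter: (4-methoxyphenyl)carbamoyl in place of (piperidin-1-yl)sulfonyl gives a 2.6-fold higher number from compound 3 to compound 4 (0.41 log units; beyond the scatter), a modest weakening. Going by these compounds alone, this is the first one-place comparison, and it shows that this swap is not tolerated without some loss. Nothing available explains the step. From the compounds shown here alone, it remains open whether the change of linking group or the added aromatic ring drives the loss. A plain acetyl group or a phenylcarbamoyl group lacking the methoxy on the same nitrogen could help separate these two parts.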